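This account rests on a few compounds, and the source may have more. Where it says the series, first, only, none or still open, it means among the compounds named here.

Measured so far in a functional assay on A549 cells (Homo sapiens) for antiproliferative activity, read by MTT assay, with a stated time of 72 h; a higher number here means a weaker inhibitor, a lower number a stronger inhibitor:
- compound 1 `COc1cccc(-c2ccc3ncn(-c4cc(OC)c(OC)c(OC)c4)c3c2)c1` gives 3180 nM
- compound 2 `COc1ccccc1-c1ccc2ncn(-c3cc(OC)c(OC)c(OC)c3)c2c1` gives 4320 nM
- compound 3 `COc1ccc(-c2ccc3ncn(-c4cc(OC)c(OC)c(OC)c4)c3c2)cc1F` gives 1430 nM

Compound 3 has the lowest number of the three. The steps to it are a 2.2-fold lower number from compound 1 to compound 3 (0.35 log units; beyond the scatter) and a 3.0-fold lower number from compound 2 to compound 3 (0.48 log units; beyond the scatter), both modest; the step of a 1.4-fold higher number from compound 1 to compound 2 (0.13 log units; within the scatter) lies within the scatter.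

Compound 4 `COc1cc(-n2cnc3ccc(-c4ccc(O)cc4)cc32)cc(OC)c1OC` is not yet measured. Its change from compound 3: 4-hydroxyphenyl in place of 3-fluoro-4-methoxyphenyl on an aromatic carbon

Going by the values given here, no measured step exchanges a methoxy for a hydroxy group or removes a fluorine, so the closest guides are the two modest steps into compound 3, which show that this position moves the number only moderately. A shift back toward the range of compound 1 is expected, as a 1.7-fold higher number from compound 3 to compound 4 (0.24 log units; within the scatter). Compound 4 is expected to give 2500 nM, between 800 nM and 8000 nM.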

Compound 4, half-maximal inhibitory concentration: 5090 nM
Estimate against measurement, compound 4: 2.0-fold (0.31 log units) below; the range from low to high includes it.
By their numbers in this assay, from the lowest: compound 3; then compounds 1, 2 and 4 (each within the scatter of the next).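

In this assay the exchange gives a 3.6-fold higher number from compound 3 to compound 4 (0.55 log units; beyond the scatter) and so removes the lead of the 3-fluoro-4-methoxyphenyl group. The steps of a 1.2-fold higher number from compound 2 to compound 4 (0.07 log units; within the scatter) and a 1.6-fold higher number from compound 1 to compound 4 (0.20 log units; within the scatter) leave the 4-hydroxyphenyl group level with the 2-methoxyphenyl and 3-methoxyphenyl groups. Compound 3 alone stands apart from the other three at this position, and no measurement shown here offers an explanation.

Open is which part of the 3-fluoro-4-methoxyphenyl group accounts for this separation. Also open, from the compounds shown here alone, is how a 4-aminophenyl or 4-carboxyphenyl group would compare at this position.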